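Solubility: From Compound 3 to Compound 4

The compounds below may be only part of what the source reports. "The series", "measured", "known", "first", "only" and "open" are said of these compounds alone.

Compound 1 `N#Cc1c(N)nc2nc(C3CCCC3)ncc2c1N`: 89000 nM
Compound 2 `N#Cc1c(N)nc2nc(Cc3ccccc3)ncc2c1N`: 13000 nM
Compound 3 `CCCCc1nc(C(C)(C)C)nc2nc(N)c(C#N)c(N)c12`: 6000 nM

In a physicochemical assay for solubility, in phosphate buffer, with a stated time of 18 h (on this read-out lower numbers stand for lower solubility and higher numbers for higher solubility), compound 3 gives 6000 nM and stands lowest of the three numbers; compound 2 lies nearest above it and compound 1 furthest above it, both gaps beyond the scatter. Compound 4 `CC(C)(C)c1nc(-c2ncc[nH]2)c2c(N)c(C#N)c(N)nc2n1` differs from compound 3 by 1H-imidazol-2-yl in place of butyl on an aromatic carbon. Among the measured compounds shown here, the only step measured in one place, a 6.8-fold lower number from compound 1 to compound 2 (0.84 log units; beyond the scatter), concerns another pair of groups and does not bear directly on this change, so the data give no measured guide to its size. A step of a 1.5-fold higher number from compound 3 to compound 4 (0.18 log units; within the scatter) is therefore expected for compound 4, upward if at all and within the scatter. Compound 4 is estimated at 9000 nM, with a range from 3000 nM to 27000 nM.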

Compound 4, solubility: < 1000 nM
Compound 4: only a limit was reported (the forecaster's own chance of this, stated with the estimate: 5%); at least 9.0-fold (0.95 log units) between middle value and limit.
By their numbers in this assay, from the lowest: compound 3; then compound 2; then compound 1. At a limit, below all of these: compound 4.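

In this assay the exchange of butyl for 1H-imidazol-2-yl gives an at least 6.0-fold lower number from compound 3 to compound 4 (0.77 log units; beyond the scatter) and so shows that this position, meta to a tert-butyl group, does not leave the number unchanged for this pair of groups. Among the compounds shown here, the only earlier step concerned other groups and could not show this. The value of compound 4 is a limit and not a number: the limit of < 1000 nM in this assay, at which 1 of the 4 values shown sits.

From the compounds shown here alone, how far the true value of compound 4 lies from that limit remains open. Also open, going by these compounds, is whether an amine or a longer chain at this position would give a number nearer that of compound 3.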